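This account rests on a few compounds, and the source may have more. Where it says the series, first, only, none or still open, it means among the compounds named here.

Working notes on the series. In a functional assay for agonist activity at Bile acid receptor (Mus musculus), read by a luciferase reporter (on this read-out lower numbers stand for an effect already at smaller amounts and higher numbers for an effect only at larger amounts of compound), compound 2 `COc1ccc(Cl)c(-c2noc(C(C)C)c2COc2ccc(-c3ccc4c(C(=O)O)cn(C)c4c3)c(C)c2)n1` gives 2000 nM, the lower of the two numbers in hand. Compound 3 `CC(C)c1onc(-c2c(Cl)cncc2Cl)c1COc1ccc(/C=C/c2cccc(C(=O)O)c2)c(Cl)c1` gives 11000 nM in this assay. Compound 1 `CC(C)c1onc(-c2ccc(S(C)(=O)=O)cc2Cl)c1COc1ccc(/C=C/c2cccc(C(=O)O)c2)c(Cl)c1` stands at a limit of the assay, > 10000 nM, and not at a number. Among the measured compounds shown here, the only step between measured compounds, a step that the limit leaves unreadable from compound 1 to compound 3, stays unreadable because the limit of > 10000 nM in this assay, at which 1 of the 3 values shown sits, caps one end of it.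

Compound 4 `Cc1cc(OCc2c(-c3ccn(C)c(=O)c3Cl)noc2C(C)C)ccc1-c1ccc2c(C(=O)O)cn(C)c2c1` differs from compound 2 by a group of 9 heavy atoms (6 carbon, 1 nitrogen, 1 oxygen, 1 chlorine; one six-membered aromatic ring with 1 hetero atom) in place of a group of 9 heavy atoms (6 carbon, 1 nitrogen, 1 oxygen, 1 chlorine; one six-membered aromatic ring with 1 hetero atom), on an aromatic carbon; the two have the same atoms, joined differently. For the measured compounds named here, no measured step touches this position, so the expected step in this assay is none beyond the scatter. The step of a 1.3-fold higher number from compound 2 to compound 4 (0.10 log units; within the scatter) is the estimated outcome. Compound 4 is expected to give 2500 nM in this assay, within 800 nM to 8000 nM.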

Compound 4, half-maximal effective concentration: 6000 nM
Compound 4: the middle estimate sits 2.4-fold (0.38 log units) below what was measured, and the stated range covers the measured number.
By their numbers in this assay, from the lowest: compound 2; then compounds 4 and 3 (each within the scatter of the next).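

In this assay, among the compounds shown here, the step of a 3.0-fold higher number from compound 2 to compound 4 (0.48 log units; beyond the scatter) is the first readable change at this position, on an aromatic carbon of the five-membered aromatic ring with 1 nitrogen and 1 oxygen. For the compounds shown here, the only earlier step cannot be read, so this is the first sign that the position responds to how the same atoms are joined: 3-chloro-6-methoxypyridin-2-yl gives way to a ring group with a double bond outside aromatic rings. Going by these compounds, it remains open how a ring with a nitrile or a trifluoromethyl in place of the chlorine would read here. Nothing measured here accounts for the step.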